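Swapping the Indole Amide for a Benzyl Carbamate

The source may report more compounds than this note shows. Statements on the series, on what has been measured and on what is new or still open speak of the compounds shown alone.

Three compounds have so far been measured in a functional assay on NFF cells (Homo sapiens) for antiproliferative activity; on this read-out higher numbers stand for weaker inhibition and lower numbers for stronger inhibition:
compound 1 `CN(C)c1ccc(C(=O)NC(CCCCCC(=O)NO)C(=O)NCc2ccccc2)cc1` gives 870 nM;
compound 2 `CC(C)CCNC(=O)C(CCCCCC(=O)NO)NC(=O)c1ccco1` gives 4400 nM;
compound 3 `O=C(CCCCC[C@H](NC(=O)c1cc2ccccc2[nH]1)C(=O)NCc1ccccc1)NO` gives 1260 nM.

Compound 3 holds the second highest of the three numbers. Its nearest neighbour is compound 1, whose number is lower, but the gap lies within the usual scatter, so the two cannot be told apart. Compound 2 sits furthest away, with a number higher by more than the scatter, so compound 2 is the weaker inhibitor of that pair.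

Compound 4 `O=C(CCCCC[C@H](NC(=O)OCc1ccccc1)C(=O)NCc1ccccc1)NO` has not yet been measured. It differs from compound 3 in one place: benzyloxy in place of 1H-indol-2-yl on a carbonyl carbon. A hydrogen-bond donor leaves and a hydrogen-bond acceptor enters, while the shared core is untouched.

Among the compounds with values here, no pair among the measured compounds differs in a single place, so there is no directly comparable step to lean on. What can be said is that all three measured numbers fall within a fairly narrow band despite quite different groups on that carbonyl carbon. The step in this assay from compound 3 to compound 4 is therefore expected to be small, if anything towards a slightly higher number, and it may well stay within the scatter. Compound 4 is estimated at 1800 nM, with a plausible range of 700 nM to 4500 nM, which corresponds to an expected step of a 1.4-fold higher number from compound 3 to compound 4 (0.15 log units; within the scatter).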

Compound 4, half-maximal inhibitory concentration: 1520 nM
Compound 4: the middle estimate sits 1.2-fold (0.07 log units) above what was measured; low and high end bracket the measured number.
By their numbers in this assay, from the lowest: compounds 1, 3 and 4 (each within the scatter of the next); then compound 2.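

In this assay, within the data shown here, the only comparison so far between compounds that differ in one place gives a 1.2-fold higher number from compound 3 to compound 4 (0.08 log units; within the scatter), so on this carbonyl carbon the two groups cannot be told apart. The change is not a trivial one on paper: 1H-indol-2-yl brings a five-membered aromatic ring and a hydrogen-bond donor, whereas benzyloxy has neither and brings a hydrogen-bond acceptor instead, so for this pair neither that ring nor that donor is needed to keep the number in the same range. No supporting measurement is available to explain why the swap leaves the read-out within the scatter.

As far as these compounds go, two groups on one carbonyl carbon say little about the range this position tolerates, so it remains open whether a small methyl or a group carrying a carboxylic acid would also stay close to compound 3 and compound 4. Also open, from the compounds shown here alone, is whether the same swap would give a similarly small step on a shared core with a longer chain.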